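The source may report more compounds than this note shows. Statements on the series, on what has been measured and on what is new or still open speak of the compounds shown alone.

Compound 3, `COc1cc(C(=O)c2sc(-c3cccc([N+](=O)[O-])c3)cc2N)cc(OC)c1OC`, is measured in a functional assay on MOLT-4 cells (Homo sapiens) for antiproliferative activity (a higher number here means a weaker inhibitor, a lower number a stronger inhibitor), at 7.5 nM, the lowest of the three numbers shown. Compound 1, `COc1cc(C(=O)c2sc(-c3cccs3)cc2N)cc(OC)c1OC`, gives in this assay 8.9 nM, and the two lie within the scatter of each other, so neither can be called the stronger. Compound 2, `COc1cc(C(=O)c2sc(-c3ccc(C(F)(F)F)cc3)cc2N)cc(OC)c1OC`, gives 250 nM, and the step of a 33-fold lower number from compound 2 to compound 3 (1.52 log units; beyond the scatter) is large.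

Compound 4, `COc1cc(C(=O)c2sc(-c3ccc(I)cc3)cc2N)cc(OC)c1OC`, differs from compound 3 in one place: 4-iodophenyl in place of 3-nitrophenyl on an aromatic carbon

For the measured compounds named here, no measured step swaps a nitro group for iodine, so the bearing of this change has to be inferred. The one phenyl ring that carries a group in the same position as the iodine here, the 4-(trifluoromethyl)phenyl of compound 2, went with a weak result: the step of a 28-fold higher number from compound 1 to compound 2 (1.45 log units; beyond the scatter) was large, and the return to a stronger number came with the 3-nitrophenyl of compound 3. On that basis a weaker result than compound 3 is expected for compound 4, though smaller than the step to compound 2, since a single group on the phenyl ring is all that is known to matter here. The expected step is an 8.0-fold higher number from compound 3 to compound 4 (0.90 log units; beyond the scatter). Compound 4 is therefore estimated at 60 nM, within a range from 15 nM to 300 nM.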

Compound 4, half-maximal inhibitory concentration: 190 nM
Compound 4: the middle estimate sits 3.2-fold (0.50 log units) below what was measured; the range from low to high includes it.
By their numbers in this assay, from the lowest: compounds 3 and 1 (each within the scatter of the next); then compounds 4 and 2 (each within the scatter of the next).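

Replacing the 3-nitrophenyl with 4-iodophenyl costs a large step in this assay (a 25-fold higher number from compound 3 to compound 4 (1.40 log units; beyond the scatter)), and replacing the thiophen-2-yl with the same group costs a step of similar size (a 21-fold higher number from compound 1 to compound 4 (1.33 log units; beyond the scatter)). Exchanging trifluoromethyl for iodo on the phenyl ring, by contrast, leaves the number within the scatter (a 1.3-fold lower number from compound 2 to compound 4 (0.12 log units; within the scatter)), so two quite different atoms or groups at this spot on the ring give results that cannot be told apart. Among these four compounds, the two with a group at that spot, compound 2 and compound 4, therefore form a weaker pair, while compound 1 and compound 3 form a stronger one, and nothing available explains this split.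

The compounds shown leave open whether the gap follows the group itself or its place on the phenyl ring, as the nitro group of compound 3 and the iodo group of compound 4 differ in both respects. Also open, from the compounds shown here alone, is how an amine or a carboxylic acid on that phenyl ring would behave in this assay.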